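The source may report more compounds than this note shows. Statements on the series, on what has been measured and on what is new or still open speak of the compounds shown alone.

Measured so far in a functional assay on RPMI-8226 cells (Homo sapiens) for antiproliferative activity, read by sulforhodamine B assay, with a stated time of 48 h; a higher number here means a weaker inhibitor of growth, a lower number a stronger inhibitor of growth:
compound 1, `COc1ccc(OC)c(/C=C/c2nnc(Nc3ccc(Cl)cc3)o2)c1`: > 100000 nM
compound 2, `COc1ccc(OC)c(/C=C/C(=O)N/N=C/c2ccc(Cl)cc2)c1`: 15700 nM

Compound 1 gives only a limit of this assay, > 100000 nM, not a number. Among the measured compounds shown here, compound 2 gives 15700 nM in this assay, and that is the only measured number in the set; the other entry is the limit of > 100000 nM in this assay, at which 1 of the 2 values shown sits. For the measured compounds named here, no step between two measured compounds that differ in a single place is available, so the series offers no measured anchor for the change discussed here.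

Compound 3, `COc1ccc(OC)c(/C=C/C(=O)N/N=C/c2ccccc2)c1`, is not yet measured. It differs from compound 2 by hydrogen in place of chloro on an aromatic carbon, the chloro sitting para to a large group; cut one bond further out, the change reads 4-chlorophenyl to phenyl. Going by the values given here, with no comparable step among the measured pairs, the expectation rests on the structural change alone: a small shift toward weaker growth inhibition is expected, with a fair chance that it stays within the usual scatter. For compound 3 the expected step in this assay is a 1.6-fold higher number from compound 2 to compound 3 (0.20 log units; within the scatter). Compound 3 is accordingly estimated at 25000 nM, within the range 8000 nM to 80000 nM.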

Compound 3, concentration for total growth inhibition: 9960 nM
The estimate for compound 3 lay 2.5-fold (0.40 log units) above the measured number; measured number inside the range.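

In this assay, among the compounds shown here, the change from 4-chlorophenyl to phenyl gives a 1.6-fold lower number from compound 2 to compound 3 (0.20 log units; within the scatter), the first measured step between two compounds that differ in one place. Compound 2 and compound 3 therefore cannot be told apart in this assay, and on this single pair the chloro on the aromatic carbon, para to a large group, is not needed for a measured number to be obtained rather than a limit. No measured property shown here bears on this step, so the result says nothing about the reason for it.

Still open, on these data alone, is whether a different group at this position, such as an amine or a carboxylic acid, would move the number beyond the scatter, since chloro and hydrogen are the only two substituents compared here. Also open, as far as these compounds go, is whether hydrogen in place of chloro would behave in the same way on the core of compound 1, whose entry of > 100000 nM is a limit of the assay and not a number.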